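The source may report more compounds than this note shows. Statements on the series, on what has been measured and on what is new or still open speak of the compounds shown alone.

Measured so far:
compound 1, `CCc1ccc(-c2nc3c(c(C)nn3-c3ccccc3)c(-c3ccccc3O)c2C#N)cc1` — 3100 nM
compound 2, `CCc1ccc(-c2nc3c(c(C)nn3-c3ccccc3)c(-c3ccccc3[N+](=O)[O-])c2C#N)cc1` — 1200 nM

In a physicochemical assay for solubility, read by spectrophotometry, in phosphate buffer, with a stated time of 18 h, at pH 7.4 (a higher number here means a more soluble compound, a lower number a less soluble compound), compound 1 gives 3100 nM, and in this assay compound 2 gives 1200 nM. Within the data shown here, of these two numbers, compound 2 stands lowest; the single measured step that connects them, a 2.6-fold lower number from compound 1 to compound 2 (0.41 log units; beyond the scatter), is described as modest but lies beyond the scatter.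

Compound 3, `CCc1ccc(-c2nc3c(c(C)nn3-c3ccccc3)c(-c3ccccc3C(F)(F)F)c2C#N)cc1`, has not yet been measured. It differs from compound 2 in one place: trifluoromethyl in place of nitro on an aromatic carbon.

Among the measured compounds shown here, no measured step exchanges these same two groups, so nothing in the data speaks directly to this change. For the measured compounds named here, the one step available only shows that replacing the group at this aromatic carbon, in the move from compound 1 to compound 2, shifted the number by a modest amount. A step of similar or smaller size, in either direction, therefore seems the most reasonable expectation, with none beyond the scatter entirely possible.

Compound 3 is expected to give about 900 nM in this assay, within a range from 300 nM to 2700 nM. The step this estimate implies, a 1.3-fold lower number from compound 2 to compound 3 (0.12 log units; within the scatter), is expected to sit close to the edge of the scatter.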

Compound 3, solubility: 11000 nM
The estimate for compound 3 lay 12-fold (1.09 log units) below the measured number; measured number above the stated range.
By their numbers in this assay, from the lowest: compound 2; then compound 1; then compound 3.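

Three groups on this aromatic carbon now show that the position can move the number in this assay both down and up, and by more than the first step suggested: nitro in place of hydroxy lowered it, whereas trifluoromethyl raises it well past both other compounds (a 9.2-fold higher number from compound 2 to compound 3 (0.96 log units; beyond the scatter), and a 3.5-fold higher number from compound 1 to compound 3 (0.55 log units; beyond the scatter)). The exchange of nitro for trifluoromethyl is therefore the largest step seen so far among these compounds, even though the two groups are close in size by heavy-atom count and neither adds a ring or a net charge. Among these compounds, nothing measured here accounts for why this exchange moves the number so far, so the step stands as an observation only.

On these data alone, three groups on a single carbon of the shared core are too few to show a trend, so it remains open where an amine, a carboxylic acid, a methoxy group or a plain chlorine would fall in this order. As far as these compounds go, it is also open whether trifluoromethyl would give a similar step at another carbon of that ring or with other groups elsewhere on the shared core.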